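Lengthening the Chain: From Compound 2 to Compound 4

This account rests on a few compounds, and the source may have more. Where it says the series, first, only, none or still open, it means among the compounds named here.

Of the compounds shown here, three sharing a core have been measured in a functional assay on MCF7 cells (Homo sapiens) for cytotoxicity, read by MTT assay, with a stated time of 72 h; a lower number here means a stronger inhibitor of growth, a higher number a weaker inhibitor of growth. Compound 1 `COc1ccc(CNc2nc([Se]C)nc3ccccc23)cc1` gives 42200 nM. Compound 3 `[SeH]c1nc([SeH])c2ccccc2n1` gives 2920 nM. Compound 2 `CSc1nc(NCCCc2ccccc2)c2ccccc2n1` gives 77200 nM, the highest of the three numbers: its gap to compound 1 is within the usual scatter, while its gap to compound 3 lies beyond it. Compound 4 `CSc1nc(NCCCCc2ccccc2)c2ccccc2n1` has not yet been measured; it differs from compound 2 by benzyl in place of phenyl on a saturated chain carbon, three bonds along the chain from a nitrogen on an aromatic ring. Going by the values given here, no measured pair shows what such a change does in this assay, so no shift beyond the scatter is expected in either direction. For compound 4 the value in this assay is estimated at 65000 nM, with a range from 25000 nM to 170000 nM, which corresponds to an expected step of a 1.2-fold lower number from compound 2 to compound 4 (0.07 log units; within the scatter).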

Compound 4, concentration for 50% growth inhibition: 32000 nM
Compound 4: the middle estimate sits 2.0-fold (0.31 log units) above what was measured, and the stated range covers the measured number.
By their numbers in this assay, from the lowest: compound 3; then compounds 4, 1 and 2 (each within the scatter of the next, the first and the last beyond it).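

In this assay, going by these compounds alone, benzyl in place of phenyl on a saturated chain carbon, three bonds along the chain from a nitrogen on an aromatic ring, gives a 2.4-fold lower number from compound 2 to compound 4 (0.38 log units; beyond the scatter) as the first measured step at this position. This modest step lies beyond the scatter, so the number at this position does respond to this change. Nothing available explains the step.

As far as these compounds go, whether a longer chain would lower the number further remains open. So does the effect of an amine or a carboxylic acid on the phenyl ring at the chain's end.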